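Pyridinyl Exchanged for Fluorophenyl on the Sulfonamide Arm

The compounds below may be only part of what the source reports. "The series", "measured", "known", "first", "only" and "open" are said of these compounds alone.

Three hydroxamic acids sharing one core have been measured in an assay on isolated protein for inhibition of protein deacetylase HDAC6 (Homo sapiens), read by mobility shift assay; on this read-out lower numbers stand for stronger inhibition and higher numbers for weaker inhibition. Compound 1 `O=C(NO)c1ccc(CN(Cc2ccc(C(F)(F)F)cc2)S(=O)(=O)c2c(F)c(F)c(F)c(F)c2F)cc1` gives 45 nM, compound 2 `O=C(NO)c1ccc(CN(Cc2ccncc2)S(=O)(=O)c2c(F)c(F)c(F)c(F)c2F)cc1` gives 14 nM, and compound 3 `O=C(NO)c1ccc(CN(Cc2ccncc2)S(=O)(=O)c2cc(F)c(F)c(F)c2F)cc1` gives 11 nM. On these numbers compound 3 stands lowest, with a gap to compound 2 that lies within the scatter and a gap to compound 1 that lies beyond it. The step of a 3.2-fold lower number from compound 1 to compound 2 (0.51 log units; beyond the scatter) came with pyridin-4-yl in place of 4-(trifluoromethyl)phenyl on a saturated chain carbon bound to a sulfonamide nitrogen, while a 1.3-fold lower number from compound 2 to compound 3 (0.10 log units; within the scatter) came with hydrogen in place of fluoro on an aromatic carbon. Compound 4 `O=C(NO)c1ccc(CN(Cc2ccccc2F)S(=O)(=O)c2cc(F)c(F)c(F)c2F)cc1` differs from compound 3 by 2-fluorophenyl in place of pyridin-4-yl on a saturated chain carbon bound to a sulfonamide nitrogen. The first of these steps bears on this change: it too exchanged a ring of carbon only for the pyridin-4-yl ring at the same place. Reversing such an exchange with a different carbon-only ring is expected to move the number in this assay modestly upward. Compound 4 is therefore estimated at 25 nM, within 10 nM to 60 nM, an expected step of a 2.3-fold higher number from compound 3 to compound 4 (0.36 log units; beyond the scatter).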

Compound 4, half-maximal inhibitory concentration: 10 nM
For compound 4 the middle estimate is 2.5-fold (0.40 log units) above the measured one; measured number inside the range.
By their numbers in this assay, from the lowest: compounds 4, 3 and 2 (each within the scatter of the next); then compound 1.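

In this assay the exchange of pyridin-4-yl for 2-fluorophenyl came with a 1.1-fold lower number from compound 3 to compound 4 (0.04 log units; within the scatter) and so, on a saturated chain carbon bound to a sulfonamide nitrogen, the two rings cannot be told apart on the core of compound 3. The ring nitrogen of pyridin-4-yl is therefore not needed for a number of this size, and the earlier step, with a 3.2-fold lower number from compound 1 to compound 2 (0.51 log units; beyond the scatter) as 4-(trifluoromethyl)phenyl left, cannot be read as a gain from pyridin-4-yl over every carbon-only ring. Nothing measured here accounts for the match of these two rings.

Going by these compounds, whether the fluoro on 2-fluorophenyl plays any part stays open, since no unsubstituted phenyl stands beside it. On these data alone, how a piperidine, a carboxylic acid or a longer chain would read at this place also stays open.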